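The source may hold more compounds than are shown below. What is called first, only, known or untested is meant among the compounds shown, and "the series" means these compounds.

Compound 3, whose structure is `C=CCc1c(O)cc(O)c2c1OC(c1ccc(OC)cc1)CC2=O`, gives 81% in a functional assay on aorta (Rattus norvegicus, strain Sprague-Dawley) for inhibition, with a stated time of 20 min; on this read-out lower numbers stand for smaller maximal responses and higher numbers for larger maximal responses. Among the three measured numbers it stands second highest: its nearest neighbour is compound 2, with structure `C=CCc1c(O)cc(O)c2c1OC(c1ccc(Cl)cc1)CC2=O`, which gives 77.6%; the step of a number 3.4 percentage points higher from compound 2 to compound 3 (within the scatter) comes from replacing chloro with methoxy on an aromatic carbon. Going by the values given here, the furthest number is that of compound 1, with structure `C=CCc1c(O)cc(O)c(C(=O)/C=C/c2ccc(O)cc2)c1O`, which gives 108%, a gap beyond the scatter, though compound 1 differs from compound 3 in more than one place and no single step links them.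

Compound 4 has the structure `C=CCc1c(O)cc(O)c2c1OC(c1ccc(O)cc1)CC2=O`. It differs from compound 3 as follows: hydrogen in place of methyl on an oxygen on an aromatic ring. Among the compounds with values here, no measured step changes a methyl on an oxygen on an aromatic ring, so nothing directly bears on this change. Within the data shown here, the only step at the same aryl position, from chloro to methoxy, stayed within the scatter, and the account therefore expects no step beyond the scatter in this assay for compound 4, with the expected change written as a number 3 percentage points higher from compound 3 to compound 4 (within the scatter). Compound 4 is accordingly estimated to give 84% in this assay, within a range from 68% to 100%.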

Compound 4, largest response reached (Emax), in percent of the reference or control that the assay uses: 9.86%
Compound 4: middle estimate off by 74.1 percentage points, on the high side; measured number below the stated range.
By their numbers in this assay, from the lowest: compound 4; then compounds 2 and 3 (each within the scatter of the next); then compound 1.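

In this assay, the step of a number 71.1 percentage points lower from compound 3 to compound 4 (beyond the scatter) and the step of a number 67.7 percentage points lower from compound 2 to compound 4 (beyond the scatter) show that this place on the aromatic ring is far from indifferent to its group, which the step of a number 3.4 percentage points higher from compound 2 to compound 3 (within the scatter) alone could not reveal. Chloro and methoxy give numbers within the scatter of each other, while hydroxy stands well apart from both, so the loss of the methyl on the oxygen matters here, though the pattern holds only for the shared core of compound 2, compound 3 and compound 4, and compound 1, which also carries a hydroxy on an aromatic ring, goes against it with 108%. Nothing available here explains the size of this drop.

The compounds shown leave open whether the low number belongs to hydroxy alone or would also appear with another group at this place, such as an amine, a carboxylic acid or an ethoxy group. They also leave open whether moving the hydroxy to another carbon of this aromatic ring would keep the number as low as it is for compound 4.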